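Isopropoxy for ethoxy on two cores of the series

The compounds below may be only part of what the source reports. "The series", "measured", "known", "first", "only" and "open" are said of these compounds alone.

Compound 1 `CCOc1ccc(-c2cc(C(=O)O)nn2-c2ccccc2)cc1` and compound 2 `CC(C)Oc1ccc(-c2cc(C(=O)O)nn2-c2ccccc2)cc1` share one core; in an assay for displacement of a labelled ligand from E3 ubiquitin-protein ligase Mdm2 (Homo sapiens), read by fluorescence polarization, with a stated time of 30 min (on this read-out higher numbers stand for weaker inhibition and lower numbers for stronger inhibition), compound 1 gives 3260 nM and compound 2 gives 2290 nM. Going by the values given here, the only change between them is methyl in place of hydrogen on a saturated chain carbon bound to an oxygen on an aromatic ring and a saturated chain carbon and it made the step of a 1.4-fold lower number from compound 1 to compound 2 (0.15 log units; within the scatter). Compound 3 `CCOc1ccc(-c2c(NC(=O)c3ccc(OC(C)C)cc3)c(C(=O)O)nn2-c2ccc(Oc3ccccc3)cc2)cc1` carries a larger core whose difference from the core of compound 1 is not broken down here; in this assay compound 3 gives 301 nM, the lowest of the three numbers. Compound 4 `CC(C)Oc1ccc(C(=O)Nc2c(C(=O)O)nn(-c3ccc(Oc4ccccc4)cc3)c2-c2ccc(OC(C)C)cc2)cc1` has not yet been measured. It differs from compound 3 by methyl in place of hydrogen on a saturated chain carbon bound to an oxygen on an aromatic ring and a saturated chain carbon, the same change at the same place as from compound 1 to compound 2. A small step is expected, a 1.3-fold lower number from compound 3 to compound 4 (0.12 log units; within the scatter), because the same change earlier gave a 1.4-fold lower number from compound 1 to compound 2 (0.15 log units; within the scatter). Compound 4 is therefore estimated at about 230 nM in this assay.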

Compound 4, inhibition constant: 107 nM
Compound 4: middle estimate off by 2.1-fold (0.33 log units), on the high side; the whole stated range lies above it.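

Ethoxy to isopropoxy on the larger core gives a 2.8-fold lower number from compound 3 to compound 4 (0.45 log units; beyond the scatter) in this assay and so counts as a real, modest step on that core. Set beside the step on the smaller core, the two do not separate: the same change on two cores in this assay, a 1.4-fold lower number (0.15 log units; within the scatter) from compound 1 to compound 2 and a 2.8-fold lower number (0.45 log units; beyond the scatter) from compound 3 to compound 4, 2.0-fold (0.30 log units) apart, within the scatter of two such steps

These two pairs allow the change to be treated as a step of similar size on both cores; they do not show that the larger core enlarges it, nor how it would behave on any further core.

Open, going by these compounds, is how a tert-butyl or cyclopropylmethyl group would read in place of the isopropyl on the same oxygen. Also open, on these data alone, is whether the step would survive with a primary amide in place of the carboxylic acid.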